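A few compounds are considered here, and "the series" means these few. Any claim that something is new, unique, unknown or untested is made for them only; others in the source may bear on it.

Two compounds share a core. Compound 1 `COc1cccc(NC(=O)NCC2(c3ccccc3)CCCCC2)c1` carries a 3-methoxyphenyl, compound 2 `O=C(NCC1(c2ccccc2)CCCCC1)Nc1ccc(I)cc1` a 4-iodophenyl. In an assay on microsomes from intestine for inhibition of acyl-CoA:cholesterol acyltransferase (Oryctolagus cuniculus) (a higher number here means a weaker inhibitor, a lower number a stronger inhibitor), compound 1 gives 2500 nM and compound 2 gives 2300 nM; the step of a 1.1-fold lower number from compound 1 to compound 2 (0.04 log units; within the scatter) is within the scatter, so the two values stand together. Compound 3 `O=C(NCC1(c2ccccc2)CCCCC1)Nc1cccc(Cl)c1Cl` is not yet measured; it differs from compound 2 by 2,3-dichlorophenyl in place of 4-iodophenyl on an amide-type nitrogen. Among the measured compounds shown here, the single step measured so far on that aryl group, a 1.1-fold lower number from compound 1 to compound 2 (0.04 log units; within the scatter), stayed within the scatter, so no step beyond the scatter is expected in this assay for compound 3. Compound 3 is estimated at 2500 nM, with a range from 900 nM to 7000 nM. This means an expected step of a 1.1-fold higher number from compound 2 to compound 3 (0.04 log units; within the scatter).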

Compound 3, half-maximal inhibitory concentration: 1300 nM
Estimate against measurement, compound 3: 1.9-fold (0.28 log units) above; measured number inside the range.
By their numbers in this assay, from the lowest: compounds 3, 2 and 1 (each within the scatter of the next).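

In this assay, with 2,3-dichlorophenyl in place of the other aryl groups on the amide-type nitrogen, the steps of a 1.8-fold lower number from compound 2 to compound 3 (0.25 log units; within the scatter) and a 1.9-fold lower number from compound 1 to compound 3 (0.28 log units; within the scatter) both stay within the scatter. A third aryl group, now carrying two chlorine atoms instead of one iodine or a methoxy, therefore still gives no step beyond the scatter at this position. No evidence on the cause of this is at hand. On these data alone, whether an aryl group bearing an amine or a carboxylic acid, or a longer chain in its place, would give a step beyond the scatter remains open, as do changes elsewhere on the shared core.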